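The source may report more compounds than this note shows. Statements on the series, on what has been measured and on what is new or still open speak of the compounds shown alone.

Series on a shared core, varied only in the aromatic group attached to it. Compound 1 `CC(Oc1ccccc1-c1cccnc1)C1=NCCN1` gives 0.5 in a functional assay on CHO cells for agonist activity at Alpha-2B adrenergic receptor (Homo sapiens); a lower number here means a smaller maximal response, a higher number a larger maximal response. Compound 2 `CC(Oc1ccccc1-c1ccncc1)C1=NCCN1` returns only the limit < 0.3 in this assay, not a number. Compound 3 `CC(Oc1ccccc1-c1ccccn1)C1=NCCN1` likewise returns the limit < 0.3 in this assay. The steps a number at least 0.20 lower from compound 1 to compound 2 (beyond the scatter) and a number at least 0.20 lower from compound 1 to compound 3 (beyond the scatter) both run down to the limit of < 0.3 in this assay, at which 2 of the 3 values shown sit, while a step that the two limits leave unreadable from compound 2 to compound 3 cannot be sized. For the measured compounds named here, compound 3 thus stands at the limit, with compound 1 holding the only number in the set. Compound 4 `CC(Oc1ccccc1-c1ccc(O)cc1)C1=NCCN1` carries 4-hydroxyphenyl in place of pyridin-2-yl on an aromatic carbon. Going by the values given here, no measured step covers the entry of a 4-hydroxyphenyl group, so the expectation is loosely held. A rise is expected, a number at least 0.10 higher from compound 3 to compound 4 (that floor lies within the scatter), though a further limit result stays plausible. Compound 4 is estimated at 0.4, between 0.2 and 0.6.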

Compound 4, intrinsic activity: the largest response reached, as a fraction of the reference agonist's: < 0.3
Compound 4 gave a limit, no number; the forecaster's own chance of this, stated with the estimate: 35%; middle value at least 0.10 from the limit.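

Replacing pyridin-3-yl with 4-hydroxyphenyl, a ring of carbon only, gives a number at least 0.20 lower from compound 1 to compound 4 (beyond the scatter), so the drop at this position does not depend on a pyridine ring being present. The steps among compounds 2, 3 and 4 cannot be read, and no order among those groups follows. For the compounds shown here, compound 1 remains the only compound with a number in this assay, and the rest of the set gives only a limit: the limit of < 0.3 in this assay, at which 3 of the 4 values shown sit.

As far as these compounds go, whether a plain phenyl or an aminophenyl group would give a number in this assay remains open. The effect of the hydroxyl group itself also remains unresolved.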